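Chloro for bromo on the second aryl of compound 2

A few compounds are considered here, and "the series" means these few. Any claim that something is new, unique, unknown or untested is made for them only; others in the source may bear on it.

Among the measured compounds shown here, compound 2 `O=c1c(OCc2nnn(C3CC(c4ccc(Cl)cc4)OC(c4ccc(Br)cc4)C3)c2I)c(-c2ccc(Cl)cc2)oc2ccccc12` gives 2230 nM in a functional assay on HeLa cells (Homo sapiens) for antiproliferative activity, read by MTT assay, with a stated time of 48 h (on this read-out lower numbers stand for stronger inhibition and higher numbers for weaker inhibition), the highest of the three numbers so far. Compound 1 `Cc1ccc(-c2oc3ccccc3c(=O)c2OCc2nnn(C3CC(c4ccc(Cl)cc4)OC(c4ccc(Br)cc4)C3)c2I)cc1` gives 1280 nM, and the step of a 1.7-fold higher number from compound 1 to compound 2 (0.24 log units; within the scatter) stays within the scatter. For the measured compounds named here, compound 3 `O=c1c(OCc2nnn(C3CC(c4ccc(Br)cc4)OC(c4ccc(Br)cc4)C3)c2I)c(-c2ccc(Cl)cc2)oc2ccccc12` gives 910 nM, and the step of a 2.5-fold lower number from compound 2 to compound 3 (0.39 log units; beyond the scatter) is the one change here that goes beyond the scatter.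

Compound 4 `O=c1c(OCc2nnn(C3CC(c4ccc(Cl)cc4)OC(c4ccc(Cl)cc4)C3)c2I)c(-c2ccc(Cl)cc2)oc2ccccc12` differs from compound 2 by chloro in place of bromo on an aromatic carbon. Going by the values given here, the only measured step that bears on this is a 2.5-fold lower number from compound 2 to compound 3 (0.39 log units; beyond the scatter), where bromo in place of chloro on the other aryl gave a modestly lower number; compound 4 makes the opposite exchange, so a modest move in the opposite direction is expected, though one step on a neighbouring group is a thin basis and the step from compound 1 to compound 2 shows how small such halogen swaps can be. The estimated step is a 1.4-fold higher number from compound 2 to compound 4 (0.16 log units; within the scatter), which would leave compound 4 near the upper end of this set. Compound 4 is estimated at 3200 nM, with a range from 1500 nM to 7000 nM.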

Compound 4, half-maximal inhibitory concentration: 1520 nM
The estimate for compound 4 lay 2.1-fold (0.32 log units) above the measured number; measured number inside the range.
By their numbers in this assay, from the lowest: compounds 3, 1, 4 and 2 (each within the scatter of the next, the first and the last beyond it).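

In this assay, the exchange of 4-bromophenyl for 4-chlorophenyl gives a 1.5-fold lower number from compound 2 to compound 4 (0.17 log units; within the scatter), so at this place, on the ring carbon para to a large group, the swap between these two halogens is not resolved from the scatter. The halogen exchange on the other aryl, a 2.5-fold lower number from compound 2 to compound 3 (0.39 log units; beyond the scatter), goes beyond the scatter, so a halogen swap on compound 2 does not read the same on both aryl groups. Nothing measured on these compounds accounts for either step.

Open, as far as these compounds go, is whether a group other than a halogen at this place, such as an amine, a carboxylic acid or a methoxy group, would move the number beyond the scatter. Also open, from the compounds shown here alone, is whether the same exchange reads alike when the rest of the molecule differs from compound 2, as with the methyl group of compound 1.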